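The compounds below may be only part of what the source reports. "The series", "measured", "known", "first", "only" and "open" are said of these compounds alone.

Measured so far:
compound 1, `COc1cccc(CNCCCNc2ccnc3cc(-c4ccccc4)ccc23)c1O`, 237 10^-6 cm/s
compound 2, `COc1cccc(CNCCCNc2ccnc3cc(Cc4cccc(C(F)(F)F)c4)ccc23)c1O`, 23 10^-6 cm/s

Both numbers come from an ADME assay for permeability, using PAMPA, with a stated time of 30 min, at pH 7.4; a lower number here means that the compound crosses the layer more slowly, a higher number that the compound crosses the layer faster. Within the data shown here, compound 2 gives the lower of the two numbers, and its only neighbour is compound 1, which sits a step above it: a 10-fold lower number from compound 1 to compound 2 (1.01 log units; beyond the scatter). Among the measured compounds shown here, that step exchanged phenyl for 3-(trifluoromethyl)benzyl on the shared core, and it is the one measured step that bears on the present question.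

Compound 3, `COc1cccc(CNCCCNc2ccnc3cc(CCc4ccccc4)ccc23)c1O`, has not yet been measured in this assay . It differs from compound 2 in one place: benzyl in place of 3-(trifluoromethyl)phenyl on a saturated chain carbon bound to an aromatic carbon. Read one bond further out, the same change is 3-(trifluoromethyl)benzyl to phenethyl, so compound 3 keeps the longer link of compound 2 but loses the trifluoromethyl group, and in that sense it stands between compound 1 and compound 2. The measured step from compound 1 to compound 2 combined both of these changes, and the data do not separate them. A partial return toward compound 1 is therefore the expectation: compound 3 is estimated to give 70 10^-6 cm/s, within 25 10^-6 cm/s to 200 10^-6 cm/s, which means an expected step of a 3.0-fold higher number from compound 2 to compound 3 (0.48 log units; beyond the scatter) in this assay .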

Compound 3, apparent permeability: 23 10^-6 cm/s
Compound 3: the middle estimate sits 3.0-fold (0.48 log units) above what was measured; measured number outside the range, below it.
By their numbers in this assay, from the lowest: compounds 2 and 3 (each within the scatter of the next); then compound 1.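

In this assay, exchanging 3-(trifluoromethyl)phenyl for benzyl on a saturated chain carbon bound to an aromatic carbon gives no change at the digits printed from compound 2 to compound 3 (within the scatter), so among these compounds a number this low does not require the trifluoromethyl group. Phenethyl in place of phenyl on an aromatic carbon, with no trifluoromethyl group present, gives a 10-fold lower number from compound 1 to compound 3 (1.01 log units; beyond the scatter), so this single change matches the size of the earlier step, which had mixed the two differences together. No other measurement is available here to explain why these two compounds give the same number.

Going by these compounds, it remains open how the number depends on the chain that carries the ring, since a plain benzyl or a longer 3-phenylpropyl group at the same aromatic carbon could show whether the low number holds across chain lengths or belongs to phenethyl and 3-(trifluoromethyl)benzyl alone. On these data alone, it is also open whether an amine or a carboxylic acid on the ring of the phenethyl group would move the number in this assay or leave it where it stands.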